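Ring-nitrogen substituent swap: cyclohexyl for pyridinyl

The compounds below may be only part of what the source reports. "The series", "measured", "known", "first", "only" and "open" are said of these compounds alone.

Within the data shown here, compound 2 `Nc1ccccc1NC(=O)c1ccc(CSC(=S)N2CCN(c3ccncc3)CC2)cc1` gives the higher of the two numbers so far: in a functional assay on A-375 cells (Homo sapiens) for antiproliferative activity, read by CCK-8 assay, with a stated time of 72 h, tested at 8 uM (a lower number here means a weaker effect, a higher number a stronger effect of the compound at the concentration tested), compound 2 gives 90.7%. Its nearest neighbour is compound 1 `Nc1ccccc1NC(=O)c1ccc(CSC(=S)N2CCN(c3ccc(Cl)cc3)CC2)cc1`, which in this assay gives 29%; the step of a number 61.7 percentage points higher from compound 1 to compound 2 (beyond the scatter) is the only one measured, and it shows that the group on the amine nitrogen in the ring can move the read-out a long way.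

Compound 3 `Nc1ccccc1NC(=O)c1ccc(CSC(=S)N2CCN(C3CCCCC3)CC2)cc1` differs from compound 2 as follows: cyclohexyl in place of pyridin-4-yl on an amine nitrogen in a ring. Among the measured compounds shown here, the one measured step exchanged one six-membered aromatic ring for another; none exchanges an aromatic ring for a non-aromatic one, so there is no direct precedent for this change. What the series does say is that this position is sensitive, and that the pyridin-4-yl of compound 2 gave a large gain over the 4-chlorophenyl of compound 1 (a number 61.7 percentage points higher from compound 1 to compound 2 (beyond the scatter)). Removing that ring entirely is expected to cost some of the effect, though by an uncertain amount; the step from compound 2 to compound 3 in this assay is estimated as a number 35.7 percentage points lower from compound 2 to compound 3 (beyond the scatter). For compound 3 in this assay the estimate is 55%, within a range of 20% to 88%.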

Compound 3, a percentage reported as inhibition, at one concentration (the size of the read-out at that concentration, not a potency): 89.9%
Estimate against measurement, compound 3: 34.9 percentage points below, outside the stated range (above it).
By their numbers in this assay, from the lowest: compound 1; then compounds 3 and 2 (each within the scatter of the next).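

In this assay the exchange of the aromatic pyridin-4-yl for the non-aromatic, carbon-only cyclohexyl gives a number 0.8 percentage points lower from compound 2 to compound 3 (within the scatter), so among these compounds neither an aromatic ring nor the ring nitrogen of pyridin-4-yl on the amine nitrogen in a ring is needed for a high read-out. Among these compounds, the exchange of 4-chlorophenyl for cyclohexyl gives a number 60.9 percentage points higher from compound 1 to compound 3 (beyond the scatter), which repeats the large step first seen with pyridin-4-yl and leaves compound 1 as the one compound of the three apart from the others, so the earlier gain cannot be tied to pyridin-4-yl as such. Nothing at hand bears on the reason for this pattern.

As far as these compounds go, whether the low read-out of compound 1 goes with the chlorine or with the phenyl ring stays open, and plain phenyl would separate the two, while a smaller group such as methyl or an open-chain group such as n-hexyl would test how much of a ring this position needs. A read-out at one concentration also leaves open whether compound 2 and compound 3 would give a matching effect at other concentrations.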